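The source may hold more compounds than are shown below. What is called first, only, known or untested is meant among the compounds shown, and "the series" means these compounds.

Compound 1 `N#CC1=C(N)Oc2c(c3nc4ccccc4nc3c3ccccc23)C12C(=O)N(Cc1cnnn1-c1cccc(Cl)c1)c1ccccc12` in a functional assay on HepG2 cells (Homo sapiens) for antiproliferative activity, read by MTT assay, with a stated time of 48 h (a lower number here means a stronger inhibitor, a higher number a weaker inhibitor), gives > 50000 nM, which is a limit of the assay and not a number.
Compound 2 `N#CC1=C(N)Oc2c(c3nc4ccccc4nc3c3ccccc23)C12C(=O)N(Cc1cnnn1-c1ccccc1Br)c1ccccc12` in this assay gives > 50000 nM, again a limit of the assay rather than a number.
Compound 3 `N#CC1=C(N)Oc2c(c3nc4ccccc4nc3c3ccccc23)C12C(=O)N(Cc1cnnn1-c1ccc(S(N)(=O)=O)cc1)c1ccccc12` in this assay gives 42200 nM.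

For the measured compounds named here, of the three values shown, only that of compound 3 is an actual number; the other two sit at the limit of > 50000 nM in this assay, at which 2 of the 3 values shown sit. Compound 3 therefore stands alone as the one measurable point, and the two steps that reach it, an at least 1.1-fold lower number from compound 1 to compound 3 (0.07 log units; that floor lies within the scatter) and an at least 1.1-fold lower number from compound 2 to compound 3 (0.07 log units; that floor lies within the scatter), are read only as floors whose size falls within the usual scatter. The step between compound 1 and compound 2 cannot be read at all because both values are limits.

Compound 4 `Cc1ccc(-n2nncc2CN2C(=O)C3(C(C#N)=C(N)Oc4c3c3nc5ccccc5nc3c3ccccc43)c3ccccc32)cc1C` differs from compound 3 in one place: 3,4-dimethylphenyl in place of 4-sulfamoylphenyl on an aromatic nitrogen. Going by the values given here, this change removes the one group that sets compound 3 apart from compound 1 and compound 2 and puts a hydrocarbon-only ring in its place, closer in kind to the halophenyl groups of those two compounds. Among the compounds with values here, the steps that bear on it both run toward compound 3 and are small at their floor, so the reverse direction is expected to give a small rise at most, with a fair chance that the assay again reports only a limit. Compound 4 is therefore estimated at 60000 nM, within 25000 nM to 150000 nM, the expected step being a 1.4-fold higher number from compound 3 to compound 4 (0.15 log units; within the scatter).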

Compound 4, half-maximal inhibitory concentration: > 50000 nM
Compound 4: only a limit was reported (the forecaster's own chance of this, stated with the estimate: 60%); the middle value is on the limit's open side.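

Compound 4 gives a limit of the assay and not a number, and its 3,4-dimethylphenyl group holds carbon only, so this limit at the aromatic nitrogen is now seen with a ring that carries no halogen, unlike those of compound 1 and compound 2. In this assay, exchanging 4-sulfamoylphenyl for 3,4-dimethylphenyl gives an at least 1.1-fold higher number from compound 3 to compound 4 (0.07 log units; that floor lies within the scatter), so removing the only group shown here with a hydrogen-bond donor cannot yet be said to change the result. The steps that join compound 4 to compound 1 and compound 2 cannot be read, and the series now gathers at a single point: the limit of > 50000 nM in this assay, at which 3 of the 4 values shown sit.

The compounds shown leave open whether compound 3 truly differs from the other three, since its number and their limits are separated by no more than a floor within the usual scatter. They also leave open whether a phenyl ring bearing an amine or a carboxylic acid, or a longer chain in place of the ring on that nitrogen, would give a clearly readable number in this assay.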